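A few compounds are considered here, and "the series" means these few. Any claim that something is new, unique, unknown or untested is made for them only; others in the source may bear on it.

In a functional assay on A549 cells (Homo sapiens) for antiproliferative activity, read by MTT assay, with a stated time of 24 h (a higher number here means a weaker inhibitor, a lower number a stronger inhibitor), three compounds sharing one core have been measured. Compound 1 `Cc1cccc(NNC(=O)c2cccc(NS(=O)(=O)c3cnc(O)nc3O)c2)c1` gives > 20000 nM, which is a limit of the assay and not a number. Among the compounds with values here, compound 2 `CCCCOc1ccc(C(=O)NNC(=O)c2cccc(NS(=O)(=O)c3cnc(O)nc3O)c2)cc1` gives 7760 nM, the only true number so far. Compound 3 `Cc1ccc(C(=O)NNC(=O)c2cccc(NS(=O)(=O)c3cnc(O)nc3O)c2)cc1` gives > 20000 nM, again only a limit. Compound 3 therefore stands at the limit of > 20000 nM in this assay, at which 2 of the 3 values shown sit.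

Compound 4 `O=C(NNC(=O)c1cccc(NS(=O)(=O)c2cnc(O)nc2O)c1)c1cccc(Cl)c1` has not yet been measured. On a carbonyl carbon it carries 3-chlorophenyl in place of 4-methylphenyl on a carbonyl carbon. Within the data shown here, two measured steps bear on this. Putting methyl in place of butoxy on an aromatic carbon gave an at least 2.5-fold higher number from compound 2 to compound 3 (0.41 log units; beyond the scatter). The other is a step that the two limits leave unreadable from compound 1 to compound 3. Neither step tests a chlorine directly.

Compound 2 at 7760 nM carries the butoxy group that compound 4 lacks, so no step beyond the scatter is expected in this assay. The expected change is a number no higher from compound 3 to compound 4 (the limit leaves the size open). For compound 4 the estimated value is 20000 nM, within an expected range from 9000 nM to 40000 nM.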

Compound 4, half-maximal inhibitory concentration: 6000 nM
Compound 4: middle estimate off by 3.3-fold (0.52 log units), on the high side, outside the stated range (below it).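

Compound 1 and compound 3 both stay at a limit of the assay, not a number: the limit of > 20000 nM in this assay, at which 2 of the 4 values shown sit. Against that limit, the group on this carbonyl carbon proves able to move the result, since 3-chlorophenyl in place of 4-methylphenyl gives an at least 3.3-fold lower number from compound 3 to compound 4 (0.52 log units; beyond the scatter), and the change on the amine nitrogen gives an at least 3.3-fold lower number from compound 1 to compound 4 (0.52 log units; beyond the scatter). The long butoxy chain is also not needed for a measurable value, as 3-chlorophenyl in place of 4-butoxyphenyl gives a 1.3-fold lower number from compound 2 to compound 4 (0.11 log units; within the scatter).

The compounds shown do not separate the effect of the chlorine from that of where it sits on the ring, as the methyl and the chlorine differ in both. As far as these compounds go, whether a bromine, a nitrile or an amine on the ring would match 3-chlorophenyl also stays open.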